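The compounds below may be only part of what the source reports. "The series", "measured", "known", "first", "only" and "open" are said of these compounds alone.

Measured compounds in a functional assay on U-87MG ATCC cells (Homo sapiens) for cytotoxicity, read by MTT assay, with a stated time of 72 h; on this read-out lower numbers stand for stronger inhibition and higher numbers for weaker inhibition:
Compound 1 `COc1ccc(OC)c(/C=N/NC(=O)Nc2ccc(Oc3ccnc(-c4nncn4CCN(C)C)c3)c(F)c2)c1` gives 6400 nM.
Compound 2 `CN(C)CCn1cnnc1-c1cc(Oc2ccc(NC(=O)N/N=C/c3ccc(F)cc3Cl)cc2F)ccn1` gives 1210 nM.
Compound 3 `COc1ccc(/C=N/NC(=O)Nc2ccc(Oc3ccnc(-c4nncn4CCN(C)C)c3)c(F)c2)c(OC)c1` gives 12600 nM.

Compound 2 stands at the lowest number of the three. The step of a 5.3-fold lower number from compound 1 to compound 2 (0.72 log units; beyond the scatter) and the step of a 10-fold higher number from compound 2 to compound 3 (1.02 log units; beyond the scatter) both lie beyond the scatter, so compound 2 is the strongest inhibitor of this small set. The remaining step, a 2.0-fold higher number from compound 1 to compound 3 (0.29 log units; within the scatter), stays within the scatter.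

Compound 4 `CN(C)CCn1cnnc1-c1cc(Oc2ccc(NC(=O)N/N=C/c3ccc(F)cc3F)cc2F)ccn1` differs from compound 2 in a single place: fluoro in place of chloro on an aromatic carbon. None of the three measured steps tests this kind of exchange. The steps from compound 1 to compound 2 and from compound 2 to compound 3 each replace the whole aryl group, and the step from compound 1 to compound 3 only moves a methoxy group. What those steps do show is that the 2-chloro-4-fluorophenyl group sits with the lowest number seen so far, and compound 4 keeps most of that group, exchanging one halogen atom for another. Without a direct precedent, the expected step of a 1.7-fold higher number from compound 2 to compound 4 (0.22 log units; within the scatter) is small, leaning towards a slightly higher number but quite possibly within the scatter. Compound 4 is therefore estimated at 2000 nM, with a range from 900 nM to 4500 nM.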

Compound 4, half-maximal inhibitory concentration: 1900 nM
Compound 4: the middle estimate sits 1.1-fold (0.02 log units) above what was measured; low and high end bracket the measured number.
By their numbers in this assay, from the lowest: compounds 2 and 4 (each within the scatter of the next); then compounds 1 and 3 (each within the scatter of the next).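

In this assay, among these compounds, the exchange of chloro for fluoro on this aromatic carbon, ortho to a large group, is the first direct test of this position, and it gives a 1.6-fold higher number from compound 2 to compound 4 (0.20 log units; within the scatter), so the data do not separate these two halogens here. The low numbers are therefore not tied to chlorine: the 2,4-difluorophenyl group also stays clear of both dimethoxyphenyl groups, with a 6.6-fold lower number from compound 3 to compound 4 (0.82 log units; beyond the scatter) and a 3.4-fold lower number from compound 1 to compound 4 (0.53 log units; beyond the scatter), and among these four compounds none goes against this split between the halogen-bearing and the methoxy-bearing aryl groups. No measurement is available that would explain these differences.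

The compounds shown leave open how this position responds to a larger halogen such as bromo, or to a non-halogen group such as methyl, nitrile or plain hydrogen. They also leave open how much the fluoro group meta to this position contributes, as compound 2 and compound 4 both carry it.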